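The source may report more compounds than this note shows. Statements on the series, on what has been measured and on what is new or still open speak of the compounds shown alone.

Three carbamates sharing one core have been tested in a functional assay on HT-29 cells (Homo sapiens) for cytotoxicity, read by MTT assay, with a stated time of 72 h; on this read-out higher numbers stand for lower toxicity in this test and lower numbers for higher toxicity in this test. Compound 1 `COc1ccc(OC(=O)Nc2ccc([Se]C#N)cc2)cc1` gives 69600 nM, compound 2 `CC(C)COC(=O)Nc1ccc([Se]C#N)cc1` gives 63700 nM, and compound 3 `Cc1ccc(OC(=O)Nc2ccc([Se]C#N)cc2)cc1` gives 68700 nM. These three numbers lie close together: the gap between compound 3 and compound 1 and the gap between compound 3 and compound 2 both fall within the usual scatter, so none of the three can be told apart from the others on this read-out. Compound 4 `N#C[Se]c1ccc(NC(=O)Oc2ccccc2)cc1` has not yet been measured. It differs from compound 3 in one place: hydrogen in place of methyl on an aromatic carbon. Within the data shown here, one measured step bears on this change: a 1.0-fold lower number from compound 1 to compound 3 (0.01 log units; within the scatter), which swapped one small group for another on the same aromatic carbon and left the number essentially unchanged. Because the step of a 1.0-fold lower number from compound 1 to compound 3 (0.01 log units; within the scatter) was flat, no step beyond the scatter is expected for compound 4 in this assay, in either direction. Compound 4 is therefore estimated at 67000 nM, with an expected range from 35000 nM to 130000 nM. The expected step is a 1.0-fold lower number from compound 3 to compound 4 (0.01 log units; within the scatter).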

Compound 4, concentration lethal to 50% of the cells: 71700 nM
Beside the measured number, compound 4's estimate is 1.1-fold (0.03 log units) below it; measured number inside the range.
By their numbers in this assay, from the lowest: compounds 2, 3, 1 and 4 (each within the scatter of the next).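

In this assay, hydrogen in place of methyl on this aromatic carbon, para to a large group, gives a step within the scatter (a 1.0-fold higher number from compound 3 to compound 4 (0.02 log units; within the scatter)). Hydrogen in place of methoxy at the same carbon is also within the scatter (a 1.0-fold higher number from compound 1 to compound 4 (0.01 log units; within the scatter)), so this position now reads the same with no added group as with either small group, where the earlier step compared only two groups with each other. Phenyl in place of isobutyl on the oxygen of the carbamate is also within the scatter (a 1.1-fold higher number from compound 2 to compound 4 (0.05 log units; within the scatter)), so that swap likewise cannot be told apart on this read-out.

Going by these compounds, whether an amine, a carboxylic acid or a chlorine atom on this carbon, or a longer chain on that oxygen, would shift the number remains open. Nothing available here offers a reason for these flat results.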